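Swapping isopropyl for cyclopropyl on the shared core

The compounds below may be only part of what the source reports. "The series", "measured", "known", "first", "only" and "open" are said of these compounds alone.

Compound 1 `CC(C)n1nc(-c2cc(-c3cccs3)on2)c(C(N)=O)c1N`: 78 nM
Compound 2 `CCc1cc(-c2nn(C(C)C)c(N)c2C(N)=O)no1`: 631 nM
Compound 3 `CC(C)c1cc(-c2nn(C(C)C)c(N)c2C(N)=O)no1`: 1260 nM

In an assay on isolated protein for inhibition of proto-oncogene tyrosine-protein kinase receptor Ret (Homo sapiens), read by radiometric assay and 33P incorporation, in the presence of a further agent that is not named here (a lower number here means a stronger inhibitor, a higher number a weaker inhibitor), compound 3 gives the highest number of the three. Its nearest neighbour is compound 2, the step of a 2.0-fold higher number from compound 2 to compound 3 (0.30 log units; within the scatter) lying within the scatter, so no order between these two can be claimed. Its furthest neighbour is compound 1, and the step of a 16-fold higher number from compound 1 to compound 3 (1.21 log units; beyond the scatter) is beyond the scatter, as is an 8.1-fold higher number from compound 1 to compound 2 (0.91 log units; beyond the scatter).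

Compound 4 `CC(C)n1nc(-c2cc(C3CC3)on2)c(C(N)=O)c1N` differs from compound 3 by cyclopropyl in place of isopropyl on an aromatic carbon. Among the measured compounds shown here, none of the measured steps covers this exact change. For the measured compounds named here, the only step that bears on it, a 2.0-fold higher number from compound 2 to compound 3 (0.30 log units; within the scatter), shows that going between two saturated groups of this size moved the number little in this assay, whereas the larger shifts an 8.1-fold higher number from compound 1 to compound 2 (0.91 log units; beyond the scatter) and a 16-fold higher number from compound 1 to compound 3 (1.21 log units; beyond the scatter) belong to the aromatic thiophen-2-yl group, which is not involved here. Compound 4 is therefore expected to show a step of a 1.6-fold lower number from compound 3 to compound 4 (0.20 log units; within the scatter) that stays within the scatter. Compound 4 is estimated at 800 nM, with a range from 250 nM to 2500 nM.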

Compound 4, half-maximal inhibitory concentration: 44 nM
Compound 4: the middle estimate sits 18-fold (1.26 log units) above what was measured; measured number outside the range, below it.
By their numbers in this assay, from the lowest: compounds 4 and 1 (each within the scatter of the next); then compounds 2 and 3 (each within the scatter of the next).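

In this assay this position does not treat all small saturated groups alike: with heavy atoms and hydrogen-bond counts unchanged, cyclopropyl in place of isopropyl gives a 29-fold lower number from compound 3 to compound 4 (1.46 log units; beyond the scatter) and cyclopropyl in place of ethyl gives a 14-fold lower number from compound 2 to compound 4 (1.16 log units; beyond the scatter) as well. The earlier compounds shown here had only thiophen-2-yl at the low end, but a 1.8-fold lower number from compound 1 to compound 4 (0.25 log units; within the scatter) lies within the scatter, so cyclopropyl and thiophen-2-yl cannot be told apart here and an aromatic group is not required for a low number at this position. Nothing available accounts for the gap between cyclopropyl and the open-chain groups.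

The compounds shown leave open whether cyclobutyl or a plain methyl on this carbon would stay near compound 4 or near compound 3. They also leave open what a substituted cyclopropyl, such as one carrying an amine, would do.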